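The source may hold more compounds than are shown below. What is called first, only, known or untested is meant among the compounds shown, and "the series" means these compounds.

Measured compounds:
Compound 1 `Cc1cc(Cl)c(-c2ncc[nH]2)cc1NC(=O)c1ccc(OCc2ccccn2)cc1` — in a physicochemical assay for lipophilicity (on this read-out lower numbers stand for lower lipophilicity and higher numbers for higher lipophilicity), compound 1 gives > 3, a limit of the assay.
Compound 2 `Cc1ncc(-c2cc(NC(=O)c3ccc(OCc4ccccn4)cc3)c(C)cc2C)[nH]1` — in this assay compound 2 gives 2.8.
Compound 3 `Cc1csc(-c2cc(NC(=O)c3ccc(OCc4ccccn4)cc3)c(C)cc2C)n1` — in this assay compound 3 gives > 3, again a limit of the assay.

Compound 3 thus sits at the top of the numbers shown, at the limit of > 3 in this assay, at which 2 of the 3 values shown sit. Among the measured compounds shown here, the only single-point step measured is a number at least 0.20 log units higher from compound 2 to compound 3 (that floor lies within the scatter). Compound 4 `Cc1cc(C)c(-c2cccc(N)n2)cc1NC(=O)c1ccc(OCc2ccccn2)cc1` differs from compound 3 by 6-aminopyridin-2-yl in place of 4-methyl-1,3-thiazol-2-yl on an aromatic carbon. For the measured compounds named here, no measured step covers this exchange; the step from compound 2 to compound 3 bears on it only in that it also swapped the ring on that aromatic carbon, and it rose. Since compound 3 is known only as a limit, the step is expected as a number at least 0.30 log units lower from compound 3 to compound 4 (that floor lies within the scatter), downward and modest. For compound 4 the estimate in this assay is 2.7, expected within 2.2 to 3.2.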

Compound 4, distribution coefficient: > 3
Compound 4 ended at the assay's limit (the forecaster's own chance of this, stated with the estimate: 25%); middle value at least 0.30 log units from the limit.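

Replacing 2-methyl-1H-imidazol-5-yl with 6-aminopyridin-2-yl on this aromatic carbon gives a number at least 0.20 log units higher from compound 2 to compound 4 (that floor lies within the scatter). The step between compound 3 and compound 4 cannot be read: both values are limits of the assay. In this assay the six-membered 6-aminopyridin-2-yl, with its hydrogen-bond donor, ends at the same limit as the five-membered 4-methyl-1,3-thiazol-2-yl: the limit of > 3 in this assay, at which 3 of the 4 values shown sit.

On these data alone, how the groups at the limit order among themselves stays open. Also open, as far as these compounds go, is whether a carboxylic acid or an aliphatic amine on this aromatic carbon would give a readable number in this assay.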